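A few compounds are considered here, and "the series" means these few. Any claim that something is new, unique, unknown or untested is made for them only; others in the source may bear on it.

Compound 1 `COc1cc(-c2cc(/C=C/C(=O)c3ccc(Cl)c(Cl)c3)[nH]n2)cc(OC)c1OC`: 14%. Compound 2 `COc1ccc(-c2cc(/C=C/C(=O)c3ccc(N)cc3)[nH]n2)cc1OC`: -86%.

In a functional assay on UACC-62 cells (Homo sapiens) for cytotoxicity, read by sulforhodamine B assay, with a stated time of 48 h, tested at 100 uM (a lower number here means a stronger effect, a higher number a weaker effect of the compound at the concentration tested), compound 1 gives 14%, the higher of the two numbers. Compound 2 gives -86% in this assay, a far lower number, and the gap lies beyond the usual scatter. Compound 3 `COc1ccc(C(=O)/C=C/c2cc(-c3cc(OC)c(OC)c(OC)c3)n[nH]2)cc1OC` has not been measured. It differs from compound 1 in a single place: 3,4-dimethoxyphenyl in place of 3,4-dichlorophenyl on a carbonyl carbon. Going by the values given here, no measured pair shows this change on its own, so its size is uncertain. The expected step is a number 24 percentage points lower from compound 1 to compound 3 (beyond the scatter), a moderate fall. Compound 3 is expected to give -10%, within -70% to 40%.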

Compound 3, a percentage reported as activity, at one concentration (the size of the read-out at that concentration, not a potency): -93%
Beside the measured number, compound 3's estimate is 83 percentage points above it, outside the stated range (below it).
By their numbers in this assay, from the lowest: compounds 3 and 2 (each within the scatter of the next); then compound 1.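

On a carbonyl carbon, 3,4-dimethoxyphenyl in place of 3,4-dichlorophenyl gives a number 107 percentage points lower from compound 1 to compound 3 (beyond the scatter) in this assay. With the rest of the molecule unchanged, the group at this position can therefore shift the read-out strongly on its own. Nothing available explains why these two groups differ so much.

This is a single swap, read at one concentration, so it says nothing about potency. From the compounds shown here alone, how a phenyl ring carrying a hydroxyl group or a carboxylic acid would behave at this position remains open.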